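The compounds below may be only part of what the source reports. "The series", "measured", "known", "first", "only" and "open" are said of these compounds alone.

Measured in an assay on cells for agonist activity at ecdysone receptor (Bombyx mori), read by a luciferase reporter, with a stated time of 24 h; a higher number here means that more compound is needed for the effect, a lower number that less compound is needed:
compound 1, `Cc1cc(C)cc(C(=O)N(NC(=O)c2ccccc2)C(C)(C)C)c1`: 69.2 nM
compound 2, `CC(C)(C)N(NC(=O)c1cccc(Cl)c1)C(=O)c1ccccc1Cl`: 155 nM
compound 3, `CC(C)(C)N(NC(=O)c1cccc(Cl)c1Cl)C(=O)c1ccccc1Cl`: 9.33 nM

Compound 2 and compound 3 differ by chloro in place of hydrogen on an aromatic carbon, and this change gave a 17-fold lower number from compound 2 to compound 3 (1.22 log units; beyond the scatter). The difference between the core of compound 1 and the core of compound 2 is not broken down here; their values alone show compound 1 with the lower number of the two in this assay.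

Compound 4, `Cc1cc(C)c(Cl)c(C(=O)N(NC(=O)c2ccccc2)C(C)(C)C)c1`, is not yet measured. It differs from compound 1 by chloro in place of hydrogen on an aromatic carbon. This is the same kind of change as from compound 2 to compound 3, not the same: there the entering chloro sits ortho to a chloro group, here it sits ortho to a methyl group and para to a methyl group, and the ring bearing it also carries a second methyl in compound 1 that compound 2 lacks. Among the compounds with values here, a step in the same direction is expected, a 4.1-fold lower number from compound 1 to compound 4 (0.61 log units; beyond the scatter), kept smaller because a 17-fold lower number from compound 2 to compound 3 (1.22 log units; beyond the scatter) is the only step that supports it and the surroundings of the entering chloro differ. For compound 4 the expected value in this assay is 17 nM, with a range from 4 nM to 60 nM.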

Compound 4, half-maximal effective concentration: 1170 nM
Beside the measured number, compound 4's estimate is 69-fold (1.84 log units) below it; the measured number lies above the stated range.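

In this assay, chloro in place of hydrogen on an aromatic carbon gave a 17-fold higher number from compound 1 to compound 4 (1.23 log units; beyond the scatter), so the same change moved the number in opposite directions on the two cores: the same change on two cores in this assay, a 17-fold lower number (1.22 log units; beyond the scatter) from compound 2 to compound 3 and a 17-fold higher number (1.23 log units; beyond the scatter) from compound 1 to compound 4, 280-fold (2.45 log units) apart, beyond the scatter of two such steps

For this series, the result of the change does not carry from one core to the other, in direction or in size, and a step read on the core of compound 2 gives no sound basis for a forecast on the core of compound 1. It does not show what separates the two results: the entering chloro of compound 4 sits ortho to a methyl group and para to a methyl group, the cores also differ, and two steps cannot tell the surroundings of the chloro from the rest of the core.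

Still open, from the compounds shown here alone, is whether the higher number of compound 4 belongs to chloro itself or would also follow from fluoro or methoxy at the same place. Also open, going by these compounds, is whether a third core would side with either step.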